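The source may hold more compounds than are shown below. What is called first, only, known or untested is meant among the compounds shown, and "the series" means these compounds.

Working notes on the series. For the measured compounds named here, in an ADME assay on the whole organism (Mus musculus, strain BALB/c), read by LC-MS, at a dose of 3 mg/kg by the intravenous route (on this read-out higher numbers stand for higher exposure at the dose given and lower numbers for lower exposure), compound 2 `CCn1nc(C)cc1C(=O)Nc1nc2cc(C(N)=O)cc(OC)c2n1C/C=C/Cn1c(NC(=O)c2cc(C)nn2CC)nc2cc(C(N)=O)cc(OCCCNC(=O)OC(C)(C)C)c21` gives 4780 ng.h/mL, the higher of the two numbers so far, and compound 1 `CCn1nc(C)cc1C(=O)NCCCCn1c(NC(=O)c2cc(C)nn2CC)nc2cc(C(N)=O)ccc21` gives 320 ng.h/mL. The gap between these two numbers lies beyond the scatter. These two compounds differ in more than one place, so their gap says nothing direct about the next change. Compound 3 `CCn1nc(C)cc1C(=O)NCCCOc1cc(C(N)=O)cc2nc(NC(=O)c3cc(C)nn3CC)n(C/C=C/Cn3c(NC(=O)c4cc(C)nn4CC)nc4cc(C(N)=O)cc(OC)c43)c12` departs from compound 2 at a single place: 1-ethyl-3-methyl-1H-pyrazol-5-yl in place of tert-butoxy on a carbonyl carbon, with 1-ethyl-3-methyl-1H-pyrazol-5-yl in place of tert-butoxy on a carbonyl carbon. Going by the values given here, no measured pair isolates this change, so the reference point is compound 2 at 4780 ng.h/mL, and the direction remains uncertain. In this assay, a slight decrease that stays within the scatter is expected, and the estimated change is a 1.4-fold lower number from compound 2 to compound 3 (0.14 log units; within the scatter). For compound 3 the estimated value is 3500 ng.h/mL, with an expected range of 1200 ng.h/mL to 9000 ng.h/mL.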

Compound 3, area under the concentration-time curve: 4300 ng.h/mL
The estimate for compound 3 lay 1.2-fold (0.09 log units) below the measured number; low and high end bracket the measured number.
By their numbers in this assay, from the lowest: compound 1; then compounds 3 and 2 (each within the scatter of the next).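

In this assay, 1-ethyl-3-methyl-1H-pyrazol-5-yl in place of tert-butoxy on a carbonyl carbon, whose other neighbour is an amide-type nitrogen, gives a 1.1-fold lower number from compound 2 to compound 3 (0.05 log units; within the scatter). For the compounds shown here, this is the first step that isolates a single place, and the two compounds cannot be told apart on this read-out, even though the entering group brings a five-membered aromatic ring that tert-butoxy lacks. Nothing measured here accounts for this result.

Only these two groups are shown on this carbonyl carbon, so it remains open how a free amine at the end of the chain, a carboxylic acid or a longer chain would read. Compound 1 differs from compounds 2 and 3 in more than one place, so its gap to them cannot be assigned to any single group.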